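This account rests on a few compounds, and the source may have more. Where it says the series, first, only, none or still open, it means among the compounds named here.

Of the compounds shown here, three have been measured in an assay on BTI cells for inhibition of Amine oxidase [flavin-containing] B (Homo sapiens), read by fluorescence and Amplex Red, with a stated time of 15 min; on this read-out higher numbers stand for weaker inhibition and lower numbers for stronger inhibition. Compound 1, `C#CCN(C)CCCOc1ccc2c(c1)OCCC2=O`, gives 11400 nM. Compound 2, `C#CCN(C)CCCCCOc1ccc2c(c1)OCCC2=O`, gives 4 nM. Compound 3, `C#CCN(C)CCCCOc1ccc(C(C)=O)cc1`, is built on a different core and gives 56.5 nM; the difference between the core of compound 3 and the core of compound 1 is not broken down here.

Going by the values given here, the one step that can be counted is the change (2-(methyl(propargyl)amino)ethyl in place of methyl(propargyl)amino on a saturated chain carbon, three bonds along the chain from an oxygen on an aromatic ring), which brought a 2900-fold lower number from compound 1 to compound 2 (3.45 log units; beyond the scatter). Compound 3 stands with the second highest of the three numbers: its number is higher than that of compound 2 and lower than that of compound 1, and in both directions the gap is beyond the scatter.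

The unmeasured compound 4, `C#CCN(C)CCCCCCOc1ccc(C(C)=O)cc1`, is related to compound 3 by 2-(methyl(propargyl)amino)ethyl in place of methyl(propargyl)amino on a saturated chain carbon, four bonds along the chain from an oxygen on an aromatic ring. Among the compounds with values here, this is the same kind of change as the one from compound 1 to compound 2, though not the same change: in compound 1 the group sits three bonds along the chain from an oxygen on an aromatic ring, whereas in compound 3 it sits four bonds along the chain from an oxygen on an aromatic ring. Because compound 3 already gives 56.5 nM, a much smaller step than the earlier one is expected, and the step from compound 3 to compound 4 is estimated at a 3.8-fold lower number from compound 3 to compound 4 (0.58 log units; beyond the scatter). Compound 4 is therefore expected to give about 15 nM, most likely between 3 nM and 80 nM.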

Compound 4, half-maximal inhibitory concentration: 20.4 nM
Estimate against measurement, compound 4: 1.4-fold (0.13 log units) below, and the stated range covers the measured number.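

In this assay, putting 2-(methyl(propargyl)amino)ethyl in place of methyl(propargyl)amino gave a 2.8-fold lower number from compound 3 to compound 4 (0.44 log units; beyond the scatter), so the number fell on the second core as well, but the size of the fall did not carry over: the same change on two cores in this assay, a 2900-fold lower number (3.45 log units; beyond the scatter) from compound 1 to compound 2 and a 2.8-fold lower number (0.44 log units; beyond the scatter) from compound 3 to compound 4, 1000-fold (3.01 log units) apart, beyond the scatter of two such steps The direction of this change therefore held in both pairs, while the size of the step on one core gave no usable measure of the step on the other. This does not show why the two steps differ, since the pairs differ both in their core and in the place of the change, three bonds along the chain from an oxygen on an aromatic ring in one and four bonds in the other, and two pairs cannot establish a rule for the series.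

The compounds shown leave open how much of the gap belongs to the core and how much to the starting chain, a question that matching chains on both cores could settle. They also leave open whether a still longer chain would lower the number further on either core, and whether an amine carrying a second methyl group in place of the propargyl group would behave in the same way.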